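Methoxy for Fluoro on the Pendant Aryl Ring

This account rests on a few compounds, and the source may have more. Where it says the series, first, only, none or still open, it means among the compounds named here.

Compound 1 `CN(C)CCCCOC(=O)Nc1ccc(Cn2nc(-c3cccnc3)c3ccccc3c2=O)cc1`: 68000 nM
Compound 2 `COc1cccc(-c2nn(Cc3ccc(NC(=O)OCCCCN(C)C)cc3)c(=O)c3ccccc23)c1`: 17600 nM
Compound 3 `CN(C)CCCCOC(=O)Nc1ccc(Cn2nc(-c3ccccc3F)c3ccccc3c2=O)cc1`: 52500 nM

In an ADME assay on Huh-7 cells (Homo sapiens) for cytotoxicity, read by MTT assay, with a stated time of 48 h (on this read-out higher numbers stand for lower toxicity in this test and lower numbers for higher toxicity in this test), compound 3 stands second highest of the three numbers, within the scatter of compound 1 and clearly apart from compound 2. Compound 4 `COc1ccccc1-c1nn(Cc2ccc(NC(=O)OCCCCN(C)C)cc2)c(=O)c2ccccc12` differs from compound 3 by methoxy in place of fluoro on an aromatic carbon. Among the measured compounds shown here, two measured steps bear on this: a 3.0-fold higher number from compound 2 to compound 3 (0.47 log units; beyond the scatter) and a 3.9-fold lower number from compound 1 to compound 2 (0.59 log units; beyond the scatter), both showing that the compound carrying a methoxy-bearing ring gave the lowest number. The methoxy in compound 4 sits at a different place on that ring, so the transfer is uncertain. A modest downward step is nevertheless expected, a 1.8-fold lower number from compound 3 to compound 4 (0.24 log units; within the scatter), giving an estimated 30000 nM for compound 4, in a range from 12000 nM to 70000 nM.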

Compound 4, half-maximal cytotoxic concentration: 44800 nM
Compound 4: the middle estimate sits 1.5-fold (0.17 log units) below what was measured, within the range that was stated.
By their numbers in this assay, from the lowest: compound 2; then compounds 4, 3 and 1 (each within the scatter of the next).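

In this assay, methoxy in place of fluoro, ortho to a large group, makes no difference beyond the scatter (a 1.2-fold lower number from compound 3 to compound 4 (0.07 log units; within the scatter)), and the same holds for 2-methoxyphenyl in place of pyridin-3-yl (a 1.5-fold lower number from compound 1 to compound 4 (0.18 log units; within the scatter)). Where the methoxy sits does matter: 2-methoxyphenyl in place of 3-methoxyphenyl gives a clear step (a 2.5-fold higher number from compound 2 to compound 4 (0.41 log units; beyond the scatter)), so among these compounds the low number goes with the 3-methoxyphenyl ring alone, not with every methoxy-bearing ring. No evidence on hand explains this gap. Still open, from the compounds shown here alone, is how an amine or a longer ether such as ethoxy would behave on this ring.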